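A few compounds are considered here, and "the series" means these few. Any claim that something is new, unique, unknown or untested is made for them only; others in the source may bear on it.

Compound 1 `Cc1cn([C@@H]2O[C@H](CO[Si](C)(C)C(C)(C)C)[C@@]3(OS(=O)(=O)C=C3NCCC(=O)OCc3ccccc3)[C@H]2O[Si](C)(C)C(C)(C)C)c(=O)n(C)c1=O` is the starting point. In a functional assay on HEL cells (Homo sapiens) for cytotoxicity, read by microscopy (a lower number here means that less compound is tolerated, a higher number that more compound is tolerated), compound 1 gives >= 400000 nM, which is a limit of the assay rather than a number (the limit of >= 400000 nM in this assay, at which 1 of the 3 values shown sits). Two measured relatives carry smaller groups on the same amine nitrogen: compound 2 `Cc1cn([C@@H]2O[C@H](CO[Si](C)(C)C(C)(C)C)[C@@]3(OS(=O)(=O)C=C3NC(N)=O)[C@H]2O[Si](C)(C)C(C)(C)C)c(=O)n(C)c1=O` gives 16000 nM, and compound 3 `Cc1cn([C@@H]2O[C@H](CO[Si](C)(C)C(C)(C)C)[C@@]3(OS(=O)(=O)C=C3NCC(=O)C(=O)N3CCC3)[C@H]2O[Si](C)(C)C(C)(C)C)c(=O)n(C)c1=O` gives 65000 nM. Both changes moved the number down, with an at least 25-fold lower number from compound 1 to compound 2 (1.39 log units; beyond the scatter) and an at least 6.1-fold lower number from compound 1 to compound 3 (0.78 log units; beyond the scatter), while a 4.1-fold higher number from compound 2 to compound 3 (0.61 log units; beyond the scatter). Compound 4 `Cc1cn([C@@H]2O[C@H](CO[Si](C)(C)C(C)(C)C)[C@@]3(OS(=O)(=O)C=C3NCC(=O)O)[C@H]2O[Si](C)(C)C(C)(C)C)c(=O)n(C)c1=O` differs from compound 1 in one place (carboxy in place of (benzyloxycarbonyl)methyl on a saturated chain carbon bound to an amine nitrogen). Neither measured step covers carboxy, yet both replacements of the benzyl ester end with a smaller polar group lowered the number, so a downward step of an at least 2.6-fold lower number from compound 1 to compound 4 (0.42 log units; beyond the scatter) is expected in this assay. Compound 4 is therefore estimated at 150000 nM, between 40000 nM and 400000 nM.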

Compound 4, minimum cytotoxic concentration: 300000 nM
Beside the measured number, compound 4's estimate is 2.0-fold (0.30 log units) below it, within the range that was stated.
By their numbers in this assay, from the lowest: compound 2; then compound 3; then compound 4. At a limit, above all of these: compound 1.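

Replacing (benzyloxycarbonyl)methyl with carboxy gives an at least 1.3-fold lower number from compound 1 to compound 4 (0.12 log units; that floor lies within the scatter), so this change need not lower the number at all. The size of that step stays unknown because compound 1 stands at a limit: the limit of >= 400000 nM in this assay, at which 1 of the 4 values shown sits.

The end of the group on this amine nitrogen still matters in this assay, with a 4.6-fold higher number from compound 3 to compound 4 (0.66 log units; beyond the scatter) and a 19-fold higher number from compound 2 to compound 4 (1.27 log units; beyond the scatter), so carboxymethyl has the highest exact number of the three smaller groups.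

Going by these compounds, it remains open how a longer chain ending in carboxy, such as 2-carboxyethyl, or a simple amine at this place would compare.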